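This account rests on a few compounds, and the source may have more. Where it says the series, first, only, none or still open, it means among the compounds named here.

Of the compounds shown here, two sharing one core have been measured in an ADME assay (liver) for metabolic stability, with Liver microsome (Homo sapiens) as the target, read by LC-MS, using microsomes, tested at 1 uM; a lower number here means that the compound disappears faster, a higher number that the compound lasts longer. Compound 1 `CNc1nc(NCCCN(C)C)c2sc(-c3ccc(OC)nc3)cc2n1` carries a 6-methoxypyridin-3-yl group on the core, and in this assay compound 1 gives 3.02 h. Compound 2 `CNc1nc(NCCCN(C)C)c2sc(-c3ccc(N4CCNCC4)cc3)cc2n1` carries a larger group with a piperazine attached to a phenyl ring in the same position, and in this assay compound 2 gives 0.8 h. Within the data shown here, of these two numbers, the one for compound 1 is the higher, and the gap to compound 2 is beyond the scatter of repeated measurements, so compound 1 is the longer-lasting of the pair.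

Compound 3 `CNc1nc(NCCCN(C)C)c2sc(-c3ccoc3)cc2n1` is a new member of the series that has not yet been measured. It differs from compound 1 in one place: furan-3-yl in place of 6-methoxypyridin-3-yl on an aromatic carbon. Among the measured compounds shown here, no pair of measured compounds shows this exact change, so the step from compound 1 to compound 3 has no direct precedent in the numbers. The step from compound 1 to compound 3 is expected to be a 2.0-fold lower number from compound 1 to compound 3 (0.30 log units; within the scatter), a moderate shortening of the half-life. Compound 3 is therefore estimated to give 1.5 h, within a range from 0.6 h to 4 h.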

Compound 3, half-life: 0.87 h
For compound 3 the middle estimate is 1.7-fold (0.24 log units) above the measured one, within the range that was stated.
By their numbers in this assay, from the lowest: compounds 2 and 3 (each within the scatter of the next); then compound 1.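

In this assay, the group on the aromatic carbon next to the ring sulfur again makes a clear difference: furan-3-yl in place of 6-methoxypyridin-3-yl gives a 3.5-fold lower number from compound 1 to compound 3 (0.54 log units; beyond the scatter). Furan-3-yl is a smaller group than 6-methoxypyridin-3-yl, yet compound 3 sits within the scatter of compound 2, which carries the much larger piperazine-bearing phenyl group, so among these three compounds, a smaller group at this position does not go with a longer half-life, and compound 1 remains the longest-lasting. No independent measurement is available here to explain this difference.

The compounds shown leave open whether the longer half-life of compound 1 comes from the pyridine ring or from its methoxy group, a question that an unsubstituted pyridin-3-yl or a 4-methoxyphenyl group at the same position could help to answer. They also leave open how far this result carries over to other side chains on the shared core, for instance if a morpholine replaced the dimethylamino group, since all three compounds carry the same chain.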